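Replacement of the ring-nitrogen benzyl group by an acyl group

The source may report more compounds than this note shows. Statements on the series, on what has been measured and on what is new or still open speak of the compounds shown alone.

Measured compounds:
compound 1 `Fc1ccc(C(SCCNC2CCN(Cc3ccc(C(F)(F)F)cc3)CC2)c2ccc(F)cc2)cc1`: 190 nM
compound 2 `Fc1ccc(C(SCCNC2CCN(Cc3cc4ccccc4o3)CC2)c2ccc(F)cc2)cc1`: 120 nM
compound 3 `O=C(c1ccc(F)cc1)N1CCC(NCC[S+]([O-])C(c2ccc(F)cc2)c2ccc(F)cc2)CC1`: 77.2 nM

Compound 1 carries the highest number of the three in an assay on membranes from striatum (strain Sprague-Dawley) for displacement of a labelled ligand from sodium-dependent dopamine transporter (Rattus norvegicus), read by scintillation counting, with a stated time of 120 min; a higher number here means a weaker inhibitor, a lower number a stronger inhibitor. Compound 2 sits nearest, with a 1.6-fold lower number from compound 1 to compound 2 (0.20 log units; within the scatter), a step within the scatter. Compound 3 lies furthest, a gap beyond the scatter, but compound 3 differs from compound 1 in more than one place, so its value gives no isolated read on any single change.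

Compound 4 `CC(C)(C)C(=O)N1CCC(NCCSC(c2ccc(F)cc2)c2ccc(F)cc2)CC1` is the next member. Relative to compound 1 the change is (tert-butyl)carbonyl in place of 4-(trifluoromethyl)benzyl on an amine nitrogen in a ring. Among the compounds with values here, no measured step bears directly on this change: the only single-point step, from compound 1 to compound 2, concerns a different group on the same ring nitrogen and stayed within the scatter. A swap at this position of that sort did little; the present swap is larger in kind, but nothing measured points to a direction. Compound 4 is therefore expected near compound 1, with a 1.1-fold higher number from compound 1 to compound 4 (0.02 log units; within the scatter) estimated as no step beyond the scatter. The estimate for compound 4 is 200 nM, within 70 nM to 600 nM.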

Compound 4, inhibition constant: 352 nM
Compound 4: middle estimate off by 1.8-fold (0.25 log units), on the low side, within the range that was stated.
By their numbers in this assay, from the lowest: compounds 3, 2, 1 and 4 (each within the scatter of the next, the first and the last beyond it).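

In this assay, within the data shown here, the step to an acyl group on the ring nitrogen reads differently depending on the reference: a 1.9-fold higher number from compound 1 to compound 4 (0.27 log units; within the scatter) but a 2.9-fold higher number from compound 2 to compound 4 (0.47 log units; beyond the scatter) and so the second step is the first at this position to pass the scatter, though only modestly. The position therefore accommodates (tert-butyl)carbonyl, which has no ring and one hydrogen-bond acceptor, with a value that compound 1 cannot be separated from, while the (1-benzofuran-2-yl)methyl group of compound 2 stands apart from it. Nothing available explains this difference.

Open, on these data alone, is whether the carbonyl or the loss of the aromatic ring matters more at this nitrogen, since compound 3 differs from compound 4 in more than one place. A neopentyl group or a benzoyl group on the same nitrogen of the thioether series would separate the two.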